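A few compounds are considered here, and "the series" means these few. Any claim that something is new, unique, unknown or untested is made for them only; others in the source may bear on it.

Measured so far:
compound 1, `O=C(O)CC/C=C1\C[C@H]2C[C@@H](O)[C@H](/C=N/NC(=O)Nc3cccc(Cl)c3)[C@H]2C1`: 5200 nM
compound 2, `O=C(O)COC/C=C1/C[C@H]2C[C@@H](O)[C@H](/C=N/NC(=O)Nc3cccc(Cl)c3)[C@H]2C1`: 180 nM
compound 3, `O=C(O)COC/C=C1\C[C@H]2C[C@@H](O)[C@H](/C=N/NC(=O)Nc3ccc(Cl)c(Cl)c3)[C@H]2C1`: 180 nM

All three numbers come from a functional assay on a cell-free system (plasma) for agonist activity at thromboxane A2 receptor (Homo sapiens); a lower number here means a stronger inhibitor, a higher number a weaker inhibitor. Compound 3 stands level with compound 2 at the digits given; the two values lie within the scatter of each other, so no order between them can be read. Together they are the lowest numbers of the three. Compound 1 stands furthest from compound 3: its number is higher, and the gap lies beyond the scatter. Compound 1 also differs from compound 3 in more than one place, so what that gap belongs to is not resolved.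

Next comes compound 4, `O=C(O)COC/C=C1\C[C@H]2C[C@@H](O)[C@H](/C=N/NC(=O)Nc3cccc(Cl)c3)[C@H]2C1`, which is not yet measured in this assay. It differs from compound 3 as follows: hydrogen in place of chloro on an aromatic carbon. Compound 2 carries the same 3-chlorophenyl group as compound 4 but differs from it elsewhere, so it gives only a rough bearing.

Among the measured compounds shown here, with no directly comparable step on record, the expectation for the step of a 1.7-fold higher number from compound 3 to compound 4 (0.22 log units; within the scatter) in this assay is a small move toward a higher number, possibly none beyond the scatter. Compound 4 is therefore expected to give about 300 nM, with a range from 100 nM to 1000 nM.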

Compound 4, half-maximal inhibitory concentration: 1600 nM
Compound 4: the middle estimate sits 5.3-fold (0.73 log units) below what was measured; the whole stated range lies below it.
By their numbers in this assay, from the lowest: compounds 2 and 3 (each within the scatter of the next); then compound 4; then compound 1.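

In this assay, the chloro group that leaves the 3,4-dichlorophenyl group matters at this aromatic carbon: the change to 3-chlorophenyl, with hydrogen in its place, gives an 8.9-fold higher number from compound 3 to compound 4 (0.95 log units; beyond the scatter), so this position is not indifferent to substitution on the background of compound 3. Among the compounds shown here, with the 3-chlorophenyl group held constant, carboxymethoxy in place of carboxymethyl on the chain gives a 3.3-fold lower number from compound 1 to compound 4 (0.51 log units; beyond the scatter), the first reading of that change alone and one that favours the carboxymethoxy chain. The double bond also carries weight, with an 8.9-fold higher number from compound 2 to compound 4 (0.95 log units; beyond the scatter) and the drawn Z form giving the lower number, and that step can be tied to configuration alone: the fact that compounds 2 and 4 differ only in the configuration as drawn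

Going by these compounds, it stays open whether the step seen on removing this chloro group holds with the double bond drawn Z, or whether the two changes together would shift the number by a different amount. Also open, on these data alone, is how fluoro, methyl or methoxy on this aromatic carbon would compare with chloro and hydrogen, and whether any of them would bring the number closer to that of compound 3.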